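The compounds below may be only part of what the source reports. "The series", "measured", "known", "first", "only" and "open" are said of these compounds alone.

In a functional assay on thoracic aorta (Rattus norvegicus, strain Wistar), with a stated time of 15 min (a lower number here means that less compound is needed, a higher number that more compound is needed for the effect), compound 1 (`Cc1ccc(S(=O)(=O)N(C)C(=O)NC(C)c2cc(Br)ccc2OCc2ccccc2)cc1`) gives 67100 nM as the middle of three numbers. Compound 2 (`COc1ccc(Br)cc1C(C)NC(=O)N(C)S(=O)(=O)c1ccc(C)cc1`) gives 19100 nM at the low end and compound 3 (`Cc1ccc(S(=O)(=O)NC(=O)NC(C)c2cc(Br)ccc2OCc2ccccc2)cc1`) gives 138000 nM at the high end. Compound 4 (`Cc1ccc(S(=O)(=O)N(C)C(=O)NC(C)c2ccccc2OCc2ccccc2)cc1`) differs from compound 1 by one change (hydrogen in place of bromo on an aromatic carbon), hydrogen in place of bromo on an aromatic carbon. Within the data shown here, no measured pair tests that place. The two measured steps lie elsewhere in the molecule, namely a 3.5-fold lower number from compound 1 to compound 2 (0.55 log units; beyond the scatter) for hydrogen in place of phenyl and a 2.1-fold higher number from compound 1 to compound 3 (0.31 log units; beyond the scatter) for hydrogen in place of methyl, and both are modest. They bear on size only, so a modest step at most is expected in this assay with no direction favoured. The step expected runs a 1.1-fold higher number from compound 1 to compound 4 (0.05 log units; within the scatter) on this estimate. Compound 4 is expected at 75000 nM with a range from 28000 nM to 200000 nM in this estimate.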

Compound 4, half-maximal effective concentration: 31000 nM
For compound 4 the middle estimate is 2.4-fold (0.38 log units) above the measured one, within the range that was stated.
By their numbers in this assay, from the lowest: compounds 2 and 4 (each within the scatter of the next); then compound 1; then compound 3.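

In this assay, among these compounds, the first reading at this aromatic carbon, para to a benzyloxy group, is a 2.2-fold lower number from compound 1 to compound 4 (0.34 log units; beyond the scatter) when hydrogen replaces bromo. The bromo is therefore not needed for the effect on the core of compound 1, and less compound is needed without it. Nothing measured here accounts for this step.

The compounds shown leave open how chloro, methoxy or an amine would stand at this position. They also leave open whether losing the bromo gives a like step from compound 2 or compound 3.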